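A Smaller Amine on the Shared Core

A few compounds are considered here, and "the series" means these few. Any claim that something is new, unique, unknown or untested is made for them only; others in the source may bear on it.

Of the compounds shown here, two have numbers so far. Compound 1 `Cc1cc2cc(NC(=O)/C=C/c3ccco3)ccc2[nH]1` gives 22300 nM in an assay on cells for inhibition of TP53-binding protein 1 (Homo sapiens), read by AlphaScreen, with a stated time of 30 min; a lower number here means a stronger inhibitor, a higher number a weaker inhibitor. Compound 2 `Cc1cc(N2CCCCC2)nc2ccc(NC(=O)/C=C/c3ccco3)cc12`, which carries a piperidin-1-yl group, gives 15100 nM in this assay. Going by the values given here, compound 2 therefore stands at the lower of the two numbers, yet its only neighbour, compound 1, sits within the scatter of it, so the two cannot be ranked against each other.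

Compound 3 `Cc1cc(N(C)C)nc2ccc(NC(=O)/C=C/c3ccco3)cc12` has not yet been measured in this assay. It differs from compound 2 in one place: dimethylamino in place of piperidin-1-yl on an aromatic carbon. Among the compounds with values here, no step between two measured compounds is available to calibrate such a change, so the expectation rests on the fact that compound 1 and compound 2, with quite different substitution, give values within the scatter of each other. On that basis the step from compound 2 to compound 3 is expected to be small, a 1.3-fold higher number from compound 2 to compound 3 (0.12 log units; within the scatter), and most likely no larger than the scatter. Compound 3 is thus estimated at 20000 nM, with a range from 8000 nM to 50000 nM.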

Compound 3, half-maximal inhibitory concentration: 4200 nM
Beside the measured number, compound 3's estimate is 4.8-fold (0.68 log units) above it; the measured number lies below the stated range.
By their numbers in this assay, from the lowest: compound 3; then compounds 2 and 1 (each within the scatter of the next).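

In this assay, going by these compounds alone, the amine on this aromatic carbon next to the ring nitrogen proves to matter: dimethylamino in place of piperidin-1-yl gives a 3.6-fold lower number from compound 2 to compound 3 (0.56 log units; beyond the scatter), the first step that can be read as a change at a single place. The number falls as the six-membered non-aromatic ring leaves and a smaller group with no ring enters, while the counts of hydrogen-bond donors and acceptors stay the same. Nothing available here accounts for the step.

This single step cannot separate the loss of the ring from the loss of heavy atoms. From the compounds shown here alone, it remains open whether a pyrrolidin-1-yl or morpholin-4-yl ring, or a still smaller methylamino or unsubstituted amino group, would follow dimethylamino or piperidin-1-yl at this position.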